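Growth inhibition notes: from compound 1 to compound 3

The compounds below may be only part of what the source reports. "The series", "measured", "known", "first", "only" and "open" are said of these compounds alone.

In a functional assay on OVCAR-5 cells (Homo sapiens) for inhibition, read by CCK-8 assay, with a stated time of 72 h, tested at 10 uM (on this read-out higher numbers stand for more inhibition of growth at the one concentration tested and lower numbers for less inhibition of growth), compound 1 (`CN(C)C(=O)c1cc2cnc(Nc3ccc(NC(=O)C4(C(=O)Nc5ccccc5F)CC4)cc3)nc2n1C1CCCC1`) gives 82.6% and stands highest of the two numbers at hand. A smaller structure that does not carry the same core, compound 2 (`Nc1ccc(NC(=O)C2(C(=O)Nc3ccc(F)cc3)CC2)cc1F`), gives 9.7% and lies lower by a gap well beyond the scatter. That gap says nothing about single groups, since the two compounds differ in more than one place.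

Compound 3 (`CN(C)C(=O)c1cc2cnc(Nc3ccc(NC(=O)C4(C(=O)Nc5cccc(Br)c5)CC4)cc3)nc2n1C1CCCC1`) keeps the core of compound 1 and changes one group: 3-bromophenyl in place of 2-fluorophenyl on an amide-type nitrogen with 3-bromophenyl in place of 2-fluorophenyl on an amide-type nitrogen. Among the measured compounds shown here, no measured pair isolates a change at this place, so the size of the step cannot be read from the data. With the rest of the structure unchanged, the expectation starts from compound 1 at (82.6%) and allows only a small downward move in this assay, probably not beyond the scatter. The estimated change is (a number 7.6 percentage points lower from compound 1 to compound 3 (within the scatter)). Compound 3 is expected to give 75% with an estimated range (55% to 92%).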

Compound 3, percent growth inhibition at one concentration: 89.6%
For compound 3 the middle estimate is 14.6 percentage points below the measured one, and the stated range covers the measured number.
By their numbers in this assay, from the lowest: compound 2; then compounds 1 and 3 (each within the scatter of the next).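

In this assay, among the compounds shown here, 3-bromophenyl in place of 2-fluorophenyl on an amide-type nitrogen gives a number 7 percentage points higher from compound 1 to compound 3 (within the scatter) and is the first step that isolates this place. On the core of compound 1, this place therefore carries either halogen-bearing phenyl without a difference that can be told from the scatter, although the halogen and its place on the ring change together in this one step. No measurement at hand bears on the reason for this result.

Because the halogen and its ring place change at once, this step does not show what either change does alone, and a reading at one concentration does not show whether compound 1 and compound 3 would also stay together at lower concentrations. As far as these compounds go, it also remains open whether this place stays as permissive for groups of another kind, such as a phenyl carrying an amine or a carboxylic acid, or a longer alkyl chain in place of the aromatic ring.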